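Swapping an ester for a nitrile on a shared core

The compounds below may be only part of what the source reports. "The series", "measured", "known", "first", "only" and "open" are said of these compounds alone.

Of the compounds shown here, three have been measured in an ADME assay on MCF-10A cells (Homo sapiens) for cytotoxicity, read by sulforhodamine B assay, with a stated time of 72 h, tested at 10 uM; on this read-out lower numbers stand for a weaker effect and higher numbers for a stronger effect at the one concentration tested. Compound 1 `COc1cccc(C(=O)/C=C/c2cc(Br)cc(OC)c2O)c1` gives 33.5%. Compound 2 `COC(=O)C1=C(N)Oc2ccc(Br)cc2C1CC(=O)c1ccc(Br)cc1` gives 39.9%, and compound 3 `Cc1ccc(C(=O)CC2C(C#N)=C(N)Oc3ccc(Cl)cc32)cc1` gives 41.8%. Compound 2 stands second highest of the three numbers; its nearest is compound 3, whose number lies within the scatter of it, and compound 1, the furthest, also lies within the scatter, so no order among the three can be claimed. Going by the values given here, no step between two measured compounds that differ in a single place is available.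

Compound 4 `N#CC1=C(N)Oc2ccc(Br)cc2C1CC(=O)c1ccc(Br)cc1` has not yet been measured. It differs from compound 2 in one place: cyano in place of methoxycarbonyl on a double-bonded ring carbon. Compound 3 also carries a cyano on a double-bonded ring carbon, and its value in this assay sits close to that of compound 2, though compound 3 differs from compound 2 in more than this one place and therefore cannot serve as a direct step. On this basis compound 4 is expected to show no step beyond the scatter, an estimated a number 1.1 percentage points higher from compound 2 to compound 4 (within the scatter). The estimate for compound 4 is 41%, ranging from 28% to 54%.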

Compound 4, a percentage reported as activity, at one concentration (the size of the read-out at that concentration, not a potency): 32.6%
The estimate for compound 4 lay 8.4 percentage points above the measured number, within the range that was stated.
By their numbers in this assay, from the lowest: compounds 4, 1, 2 and 3 (each within the scatter of the next).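

The exchange of methoxycarbonyl for cyano on a double-bonded ring carbon now has a direct reading in this assay: the step is a number 7.3 percentage points lower from compound 2 to compound 4 (within the scatter), with the rest of the shared core, including both bromine-bearing rings, left the same. The methoxycarbonyl is therefore not needed at this place, next to the ring atom that bears an amino group, for the read-out to stay within the scatter, and the two groups cannot be told apart here, at a single concentration in a single cell line. Nothing measured on these compounds accounts for the result, so no reason for it can be offered.

What the compounds shown leave open is whether a carboxylic acid, a primary amide or a longer ester such as ethoxycarbonyl at the same ring carbon would give a step beyond the scatter. Going by these compounds alone, also open is whether the cyano and methoxycarbonyl groups would stay as close together on a core with other substituents, since no such matched pair is available.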